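The source may report more compounds than this note shows. Statements on the series, on what has been measured and on what is new or still open speak of the compounds shown alone.

Measured compounds:
- compound 1, `CC1=C(/C=C/C(=O)/C=C/c2ccccc2C(F)(F)F)C(C)(C)CCC1O`, 3700 nM
- compound 2, `CC1=C(/C=C/C(=O)/C=C/c2ccccc2F)C(C)(C)CCC1O`, 10400 nM
- compound 3, `CC1=C(/C=C/C(=O)/C=C/c2ccc(C(F)(F)F)cc2F)C(C)(C)CCC1O`, 4600 nM

All three were tested in a functional assay on PC-3 cells (Homo sapiens) for cytotoxicity, read by MTT assay, with a stated time of 72 h; a higher number here means a weaker inhibitor, a lower number a stronger inhibitor. Compound 2 gives the highest number of the three, beyond the scatter from both others. Compound 4, `CC1=C(/C=C/C(=O)/C=C/c2c(F)cccc2C(F)(F)F)C(C)(C)CCC1O`, differs from compound 2 by one change: trifluoromethyl in place of hydrogen on an aromatic carbon. Within the data shown here, two measured steps bear on this. Replacing trifluoromethyl by fluoro gave a 2.8-fold higher number from compound 1 to compound 2 (0.45 log units; beyond the scatter), and adding trifluoromethyl elsewhere on the same ring gave a 2.3-fold lower number from compound 2 to compound 3 (0.35 log units; beyond the scatter). Both point the same way: a trifluoromethyl on this ring goes with a lower number. A step of similar, modest size in this assay is therefore expected, downward. Compound 4 is estimated at 3500 nM, within 1500 nM to 8000 nM, meaning an expected step of a 3.0-fold lower number from compound 2 to compound 4 (0.47 log units; beyond the scatter).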

Compound 4, half-maximal inhibitory concentration: 8800 nM
For compound 4 the middle estimate is 2.5-fold (0.40 log units) below the measured one, outside the stated range (above it).
By their numbers in this assay, from the lowest: compounds 1, 3, 4 and 2 (each within the scatter of the next, the first and the last beyond it).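

In this assay, adding trifluoromethyl ortho to a large group gives a 1.2-fold lower number from compound 2 to compound 4 (0.07 log units; within the scatter) when the ring already carries fluoro, so the trend toward lower numbers seen with compound 1 and compound 3 does not hold here. A fluoro group added to the ring already carrying trifluoromethyl gives a 2.4-fold higher number from compound 1 to compound 4 (0.38 log units; beyond the scatter) in this assay. What one group does at this position therefore depends on what else the ring carries. Nothing shown explains this. As far as these compounds go, whether an amine or a methoxy group at this position would follow trifluoromethyl remains open.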